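Swapping a methoxy for ethylsulfanyl on a stomach inhibitor

The source may report more compounds than this note shows. Statements on the series, on what has been measured and on what is new or still open speak of the compounds shown alone.

Measured so far:
Compound 1, `Cc1cn2cccc(OCc3ccccc3)c2n1`, gives 70%.
Compound 2, `Cc1nc2c(OCc3ccccc3)cccn2c1C(N)=O`, gives 2%.
Compound 3, `COCc1c(C)nc2c(OCc3ccccc3)cccn12`, gives 29%.

All three numbers come from a functional assay on the whole organism (stomach) for inhibition, with Canis familiaris (Canis lupus familiaris) as the target, at a dose of 5 mg/kg by the intravenous route; on this read-out higher numbers stand for a stronger effect at the one dose given and lower numbers for a weaker effect. On these numbers compound 3 stands second highest of the three: compound 1 lies well above it, compound 2 well below it, and both gaps are beyond the scatter.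

Compound 4, `CCSCc1c(C)nc2c(OCc3ccccc3)cccn12`, has not yet been measured. It differs from compound 3 in one place: ethylsulfanyl in place of methoxy on a saturated chain carbon bound to an aromatic carbon.

Two measured steps lead into compound 3 and show that the group on this chain matters: a number 41 percentage points lower from compound 1 to compound 3 (beyond the scatter) and a number 27 percentage points higher from compound 2 to compound 3 (beyond the scatter). For the measured compounds named here, neither of them, however, exchanges a methoxy for an ethylsulfanyl; that exchange has no measured counterpart here. With nothing to point either way, no step beyond the scatter is expected in this assay, though the uncertainty is wide.

Compound 4 is therefore estimated to give 30%, within 8% to 55%. The expected step is a number 1 percentage points higher from compound 3 to compound 4 (within the scatter).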

Compound 4, a percentage reported as inhibition, in the whole organism at one dose (the size of the read-out at that dose, not a potency): 0%
Compound 4: middle estimate off by 30 percentage points, on the high side; the measured number lies below the stated range.
By their numbers in this assay, from the lowest: compounds 4 and 2 (each within the scatter of the next); then compound 3; then compound 1.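

In this assay, the group at the end of this chain matters as well as the presence of the chain: with the chain carbon kept, exchanging only methoxy for ethylsulfanyl gives a number 29 percentage points lower from compound 3 to compound 4 (beyond the scatter). Replacing the original hydrogen with the whole (ethylsulfanyl)methyl group gives a number 70 percentage points lower from compound 1 to compound 4 (beyond the scatter), so this substituent removes the effect seen for the unsubstituted compound at this dose. The (ethylsulfanyl)methyl and carbamoyl groups cannot be told apart here, with a number 2 percentage points lower from compound 2 to compound 4 (within the scatter), even though their structures differ.

Nothing available here explains why the effect disappears. From the compounds shown here alone, it remains open whether a hydroxy group, an amine or a carboxylic acid on this chain carbon would keep more of the effect, and whether a methylsulfanyl group would behave like ethylsulfanyl.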